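Phenyl to Nitro in a Closely Grouped Series

This account rests on a few compounds, and the source may have more. Where it says the series, first, only, none or still open, it means among the compounds named here.

In a functional assay on the whole organism (Cavia porcellus) with Rattus norvegicus as the target (on this read-out lower numbers stand for an effect already at smaller amounts and higher numbers for an effect only at larger amounts of compound), compound 1 (`O=c1onc2n1C=CS[C@@]2(O)c1ccc(Cl)cc1`) gives 245000000 nM and compound 2 (`CC1=C(C)n2c(noc2=O)[C@](O)(c2ccc(Cl)cc2)S1`) gives 705000000 nM there. Compound 3 (`CC1=CS[C@@](O)(c2ccc(-c3ccccc3)cc2)c2noc(=O)n21`) gives 378000000 nM and lies within the usual scatter of both. Compound 4 (`CC1=CS[C@@](O)(c2ccc([N+](=O)[O-])cc2)c2noc(=O)n21`) carries nitro in place of phenyl on an aromatic carbon, para to a large group (nitro in place of phenyl on an aromatic carbon). Among the measured compounds shown here, no two measured compounds differ in one place alone, so this expectation rests only on how close compound 3 at 378000000 nM stands to the others. In this assay the expected step of a 1.1-fold higher number from compound 3 to compound 4 (0.02 log units; within the scatter) stays within the scatter, with no clear direction. The estimate for compound 4 is 400000000 nM with an expected range from 150000000 nM to 1000000000 nM here.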

Compound 4, half-maximal effective concentration: 607000000 nM
Compound 4: the middle estimate sits 1.5-fold (0.18 log units) below what was measured, and the stated range covers the measured number.
By their numbers in this assay, from the lowest: compounds 1, 3, 4 and 2 (each within the scatter of the next, the first and the last beyond it).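

In this assay, putting nitro in place of phenyl on an aromatic carbon, para to a large group, gives a 1.6-fold higher number from compound 3 to compound 4 (0.21 log units; within the scatter). Among the compounds shown here, as the first step that changes one place alone, it shows that this exchange, despite replacing a whole aromatic ring, leaves no difference that stands clear of the scatter. Nothing available explains this result.

Going by these compounds, whether an amine or a carboxylic acid at this position would give a clear step remains open. So does whether nitro would behave the same way on the core of compound 1.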